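The compounds below may be only part of what the source reports. "The series", "measured", "known", "first", "only" and "open" are said of these compounds alone.

Measured to date in an ADME assay on HEK293 cells (Homo sapiens) for cytotoxicity, read by CellTiter-Glo, with a stated time of 72 h; on this read-out higher numbers stand for an effect only at larger amounts of compound and lower numbers for an effect already at smaller amounts:
Compound 1 `C[C@@H]1CC[C@H]2CC3=C(C(=O)O)CC[C@@]31C2(C)C`: 26000 nM
Compound 2 `COC(=O)C1=C2C[C@@H]3CC[C@@H](C)[C@]2(CC1)C3(C)C`: 26000 nM
Compound 3 `C[C@@H]1CC[C@H]2CC3=C(C=O)CC[C@@]31C2(C)C`: 26000 nM

Compound 3 stands level with compounds 1 and 2 at the digits shown; no compound of the three separates from the others. Compound 4 `C[C@@H]1CC[C@H]2CC3=C(CO)CC[C@@]31C2(C)C` differs from compound 3 by hydroxymethyl in place of formyl on a double-bonded ring carbon. The steps already measured all concern this same substituent on the double-bonded ring carbon: no change at the digits printed from compound 1 to compound 2 (within the scatter), no change at the digits printed from compound 1 to compound 3 (within the scatter) and no change at the digits printed from compound 2 to compound 3 (within the scatter). Each of these stayed within the scatter, so for a further exchange at this substituent no step beyond the scatter is expected in this assay. Compound 4 is therefore estimated at 26000 nM, expected range 13000 nM to 52000 nM. The expected step is no change at the digits printed from compound 3 to compound 4 (within the scatter).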

Compound 4, half-maximal effective concentration: 26000 nM
Beside the measured number, compound 4's estimate shows no gap at the digits printed; the range from low to high includes it.
By their numbers in this assay, from the lowest: compounds 1, 2, 3 and 4 (each within the scatter of the next).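

In this assay hydroxymethyl, which brings a hydrogen-bond donor that formyl lacks, gives no change at the digits printed from compound 3 to compound 4 (within the scatter) in place of formyl, no change at the digits printed from compound 2 to compound 4 (within the scatter) in place of methoxycarbonyl and no change at the digits printed from compound 1 to compound 4 (within the scatter) in place of carboxy. On this double-bonded ring carbon, a substituent without a carbonyl group therefore reads the same as the three that carry one.

As far as these compounds go, whether an amine or a longer chain here would separate from these four stays open, as does any change elsewhere on the shared core. No measured evidence gives a reason for this flat result.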